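Swapping chloro for nitro on the shared core

The source may report more compounds than this note shows. Statements on the series, on what has been measured and on what is new or still open speak of the compounds shown alone.

Measured compounds:
compound 1 `Fc1ccc(-c2noc(Cc3c[nH]c4ccccc34)n2)cc1` — 13600 nM
compound 2 `Clc1ccc(-c2noc(Cc3c[nH]c4ccccc34)n2)cc1` — > 50000 nM

In a functional assay on cells (Splenocyte, Mus musculus, strain BALB/c) for inhibition, read by scintillation counting and thymidine incorporation, with stated times of 48 h and 8 h (on this read-out higher numbers stand for weaker inhibition and lower numbers for stronger inhibition), compound 1 gives 13600 nM. For compound 2 the reported value > 50000 nM is a limit of the assay rather than a number. Compound 2 therefore stands at the weak end of the two values shown, sitting at the limit of > 50000 nM in this assay, at which 1 of the 2 values shown sits. The measured step of an at least 3.6-fold higher number from compound 1 to compound 2 (0.56 log units; beyond the scatter) is the only one on this aromatic carbon, and it moved toward weaker inhibition.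

Compound 3 `O=[N+]([O-])c1ccc(-c2noc(Cc3c[nH]c4ccccc34)n2)cc1` differs from compound 2 by nitro in place of chloro on an aromatic carbon. For the measured compounds named here, no measured step covers a nitro group, so the expectation rests on compound 1 and compound 2 alone: the one change seen at this position, an at least 3.6-fold higher number from compound 1 to compound 2 (0.56 log units; beyond the scatter), gave a weaker number, and compound 2 already sits at the limit. The step is expected to be small, an at least 1.6-fold lower number from compound 2 to compound 3 (0.22 log units; that floor lies within the scatter), since only a return toward the number of compound 1 or a value still at the limit seems plausible. Compound 3 is thus estimated at 30000 nM, with a range from 8000 nM to 100000 nM.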

Compound 3, half-maximal inhibitory concentration: > 50000 nM
Compound 3 was reported as a limit; the forecaster's own chance of this, stated with the estimate: 45%; at least 1.6-fold (0.22 log units) between middle value and limit.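

Compound 3 gives > 50000 nM in this assay, and this value is a limit of the assay rather than a number. Replacing fluoro with nitro on this aromatic carbon, para to a large group, gives an at least 3.6-fold higher number from compound 1 to compound 3 (0.56 log units; beyond the scatter), so both replacements of fluoro seen here, chloro and now nitro, move toward weaker inhibition, and in these three compounds only the fluoro compound gives a value that is an actual number. The step from chloro to nitro cannot be read, and chloro and nitro cannot be placed in order, since both compounds rest at the same limit: the limit of > 50000 nM in this assay, at which 2 of the 3 values shown sit.

The compounds shown leave open whether any group on this aromatic carbon can give stronger inhibition than fluoro does, since all the comparisons here start from fluoro and end at the limit. For the compounds shown here, an amine or a carboxylic acid at this place, or a plain hydrogen, could help show whether inhibition depends on what sits here or whether fluoro is simply the only one of these three groups that gives a readable number.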